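Selenium versus sulfur on the amidine carbon of the furoyl series

The source may report more compounds than this note shows. Statements on the series, on what has been measured and on what is new or still open speak of the compounds shown alone.

Measured so far:
compound 1 `C[Se]/C(=N\C(=O)c1ccco1)NC(=O)c1ccco1`: 360 nM
compound 2 `CS/C(=N\C(=O)c1ccco1)NC(=O)c1ccco1`: 56200 nM

Among the compounds with values here, in a functional assay on PC-3 cells (Homo sapiens) for cytotoxicity, read by MTT assay, with a stated time of 72 h (a higher number here means a weaker inhibitor of growth, a lower number a stronger inhibitor of growth), compound 2 gives the higher of the two numbers; the one comparison available, a 160-fold higher number from compound 1 to compound 2 (2.19 log units; beyond the scatter), is large. Compound 3 `O=C(/N=C(/NC(=O)c1ccco1)[Se]Cc1ccccc1)c1ccco1` is not yet measured. It differs from compound 2 by a group of 8 heavy atoms (7 carbon, 1 selenium; one six-membered aromatic ring of carbon only) in place of a group of 2 heavy atoms (1 carbon, 1 sulfur; no ring), on a carbon with a double bond to nitrogen. The step from compound 1 to compound 2 bears on this change only in part, since compound 3 also carries the aromatic ring. Given that step, a large downward step is expected here, a 94-fold lower number from compound 2 to compound 3 (1.97 log units; beyond the scatter). Compound 3 is estimated at 600 nM, within 120 nM to 4000 nM.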

Compound 3, concentration for 50% growth inhibition: 30500 nM
For compound 3 the middle estimate is 51-fold (1.71 log units) below the measured one; measured number above the stated range.
By their numbers in this assay, from the lowest: compound 1; then compounds 3 and 2 (each within the scatter of the next).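

In this assay, selenium on the carbon with a double bond to nitrogen does not by itself secure a low number: phenyl in place of hydrogen on the saturated chain carbon bound to selenium gives an 85-fold higher number from compound 1 to compound 3 (1.93 log units; beyond the scatter). The selenium compound 3 is also not separated from the sulfur compound 2, with a 1.8-fold lower number from compound 2 to compound 3 (0.27 log units; within the scatter). No measurement bears on the reason for either result.

Open, as far as these compounds go, is how an ethyl group on selenium would read, and whether a sulfur-bound benzyl group would match compound 3.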